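One Acetyl Group Tried on a Second Core

The source may hold more compounds than are shown below. What is called first, only, known or untested is meant among the compounds shown, and "the series" means these compounds.

Of the compounds shown here, three have been tested in a functional assay on HeLa cells (Homo sapiens) for cytotoxicity, read by MTT assay, with a stated time of 72 h; on this read-out lower numbers stand for stronger inhibition and higher numbers for weaker inhibition. Compound 1 `FC(F)(F)c1cc(/N=N/Nc2ccc(Cl)c(C(F)(F)F)c2)ccc1Cl` gives 58400 nM. Compound 2 `CC(=O)N(/N=N/c1ccc(Cl)c(C(F)(F)F)c1)c1ccc(Cl)c(C(F)(F)F)c1` differs from it by acetyl in place of hydrogen on a nitrogen on an aromatic ring and gives 50600 nM. The step of a 1.2-fold lower number from compound 1 to compound 2 (0.06 log units; within the scatter) lies within the usual scatter, so the two numbers cannot be told apart. Compound 3 `O=[N+]([O-])c1ccc(/N=N/Nc2ccc([N+](=O)[O-])cc2F)c(F)c1` is built on a different core; the difference between the two cores is not broken down here. In this assay compound 3 gives 3300 nM, the lowest of the three numbers, and its steps to compound 2 and to compound 1 both lie beyond the scatter.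

Compound 4 `CC(=O)N(/N=N/c1ccc([N+](=O)[O-])cc1F)c1ccc([N+](=O)[O-])cc1F` has not been measured yet. It stands to compound 3 as compound 2 stands to compound 1: acetyl in place of hydrogen on a nitrogen on an aromatic ring. The place of the change is described in the same words for both pairs, so it is the same change made on a second core. Among the measured compounds shown here, its only measured example is the step of a 1.2-fold lower number from compound 1 to compound 2 (0.06 log units; within the scatter), which stayed within the scatter.

With a single example, the expectation rests on that step carrying over to the new core. For compound 4 in this assay a step of about the same small size is expected, a 1.2-fold lower number from compound 3 to compound 4 (0.07 log units; within the scatter). Compound 4 is therefore estimated at 2800 nM. Compound 4 is expected to fall somewhere in the estimated range from 1000 nM to 8000 nM, a range set wide enough to allow for the two cores answering the change differently.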

Compound 4, half-maximal inhibitory concentration: 4760 nM
Estimate against measurement, compound 4: 1.7-fold (0.23 log units) below, within the range that was stated.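

In this assay, the step of a 1.4-fold higher number from compound 3 to compound 4 (0.16 log units; within the scatter) is small, so acetyl in place of hydrogen on this nitrogen leaves the two numbers of the second core indistinguishable, just as it did on the first core. Set side by side, the two steps tell the same story, and the change can be said to have carried over from one core to the other: the same change on two cores in this assay, a 1.2-fold lower number (0.06 log units; within the scatter) from compound 1 to compound 2 and a 1.4-fold higher number (0.16 log units; within the scatter) from compound 3 to compound 4, 1.7-fold (0.22 log units) apart, within the scatter of two such steps. Among the compounds shown here, this does not show that the change would be as quiet on every core, since two cores are only two examples, and the fact that one step points down and the other up cannot be read as a real difference between the cores.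

Acetyl is the only group shown on this nitrogen, so it remains open whether a longer chain such as butanoyl, a benzoyl group or a simple methyl group would also leave the number in place. On these data alone, it also remains open whether the same quiet step would hold on a core carrying other groups on its aromatic rings, such as a nitrile or an amine, or in cells other than those used here.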